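Shrinking the Oxazolidinone Side Chain on a Shared Core

The source may report more compounds than this note shows. Statements on the series, on what has been measured and on what is new or still open speak of the compounds shown alone.

Measured so far:
- compound 1, `CC(C)c1n[nH]c2c(NCc3ccc(-c4ccccn4)cc3)nc(SCC3CNC(=O)O3)nc12`: 80 nM
- compound 2, `CC(C)c1n[nH]c2c(NCc3ccc(-c4ccccn4)cc3)nc(SCCNC(=N)N)nc12`: 390 nM
- compound 3, `CC(C)c1n[nH]c2c(NCc3ccc(-c4ccccn4)cc3)nc(SC3CCCCC3O)nc12`: 636 nM

All three share one core and differ only in the group carried on the sulfur. In a functional assay on HT cells (Homo sapiens) for antiproliferative activity, read by fluorescence, with a stated time of 72 h (on this read-out lower numbers stand for stronger inhibition of growth and higher numbers for weaker inhibition of growth), compound 1 gives the lowest number of the three, so it inhibits growth most strongly among them; the other two lie beyond the scatter from it.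

Compound 4, `CC(C)c1n[nH]c2c(NCc3ccc(-c4ccccn4)cc3)nc(SCC(N)=O)nc12`, has not yet been measured. It differs from compound 1 as follows: carbamoyl in place of 2-oxo-1,3-oxazolidin-5-yl on a saturated chain carbon bound to a sulfur.

Going by the values given here, two measured steps bear on this. Replacing the oxazolidinone-bearing chain gave a 4.9-fold higher number from compound 1 to compound 2 (0.69 log units; beyond the scatter) and an 8.0-fold higher number from compound 1 to compound 3 (0.90 log units; beyond the scatter), so each swap of this group so far has weakened inhibition modestly. Carbamoyl is a still smaller group, so a weakening of similar size is expected in this assay, a step of about a 4.0-fold higher number from compound 1 to compound 4 (0.60 log units; beyond the scatter).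

Compound 4 is therefore estimated at 320 nM, expected to fall between 120 nM and 850 nM.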

Compound 4, concentration for 50% growth inhibition: 192 nM
Beside the measured number, compound 4's estimate is 1.7-fold (0.22 log units) above it; measured number inside the range.
By their numbers in this assay, from the lowest: compound 1; then compound 4; then compounds 2 and 3 (each within the scatter of the next).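

In this assay the ring of compound 1 is not essential for strong inhibition at this position: carbamoyl in its place costs some strength, with a 2.4-fold higher number from compound 1 to compound 4 (0.38 log units; beyond the scatter), yet the much smaller group still outperforms the other two replacements. The gains are a 3.3-fold lower number from compound 3 to compound 4 (0.52 log units; beyond the scatter) and a 2.0-fold lower number from compound 2 to compound 4 (0.31 log units; beyond the scatter), so the number does not simply rise as the group on the sulfur shrinks. No measurement shown here explains these differences.

From the compounds shown here alone, whether the carbamoyl nitrogen matters remains open, since a carboxylic acid or a methyl ester on the same saturated chain carbon would test that directly. Also open, going by these compounds, is how the number would respond to a longer chain between the sulfur and the carbamoyl group.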